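Piperazine nitrogen substituent on a triazine core: methyl to pyrimidinyl

This account rests on a few compounds, and the source may have more. Where it says the series, first, only, none or still open, it means among the compounds named here.

Measured compounds:
compound 1, `N#Cc1ccc(Nc2nc(Oc3ccnc4ccccc34)nc(N3CCN(C(c4ccccc4)c4ccc(Cl)cc4)CC3)n2)cc1C(F)(F)F`, in a functional assay on DU-145 cells (Homo sapiens) for cytotoxicity, read by sulforhodamine B assay, with a stated time of 48 h (on this read-out higher numbers stand for lower toxicity in this test and lower numbers for higher toxicity in this test), compound 1 gives > 100000 nM.
compound 2, `CN1CCN(c2nc(Nc3ccc(C#N)c(C(F)(F)F)c3)nc(Oc3ccnc4ccccc34)n2)CC1`, in this assay compound 2 gives > 100000 nM.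
compound 3, `COc1ccc(CN2CCN(c3nc(Nc4ccc(C#N)c(C(F)(F)F)c4)nc(Oc4ccnc5ccccc45)n3)CC2)c(OC)c1OC`, in this assay compound 3 gives > 100000 nM.

Every value shown for compound 2 is a limit of the assay rather than a number, so compound 2 cannot be placed more precisely than that: it sits at the limit in this assay, and the same is true of the two other values shown, as summarised by the limit of > 100000 nM in this assay, at which 3 of the 3 values shown sit.

The unmeasured compound 4, `N#Cc1ccc(Nc2nc(Oc3ccnc4ccccc34)nc(N3CCN(c4ncccn4)CC3)n2)cc1C(F)(F)F`, differs from compound 2 in one place: pyrimidin-2-yl in place of methyl on an amine nitrogen in a ring. Going by the values given here, the only single-site step measured so far, a step that the two limits leave unreadable from compound 2 to compound 3, starts from the same compound 2 and changes the same ring nitrogen, but it is unreadable, since both of its ends are limits. The step from compound 1 to compound 2 is not a single-site change, and its two values show only that both sit at the limit.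

With all three values at the limit and no readable step, no direction and no size can be assigned to the change from compound 2 to compound 4 beyond what the limit allows. Compound 4 is therefore expected to remain near the limit, with an estimated 150000 nM in this assay and a range from 40000 nM to 500000 nM, corresponding to an expected step that the limit leaves unreadable from compound 2 to compound 4.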

Compound 4, concentration lethal to 50% of the cells: > 100000 nM
Compound 4: only a limit was reported (the forecaster's own chance of this, stated with the estimate: 85%); the middle value lies beyond the limit too.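

In this assay compound 4 gives > 100000 nM, which is a limit of the assay and not a number. Compound 2 also stands only at a limit, so no step can be read between compound 2 and compound 4. The compounds shown leave open whether any group on that ring nitrogen changes the read-out at all: the limit of > 100000 nM in this assay, at which 4 of the 4 values shown sit.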